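This account rests on a few compounds, and the source may have more. Where it says the series, first, only, none or still open, it means among the compounds named here.

Measured so far:
- compound 1, `Cc1nc(S(C)(=O)=O)ccc1Oc1ncnc(OC2CCN(C(=O)SC(C)C)CC2)c1F`: in a functional assay on isolated protein for inhibition of Glucose-dependent insulinotropic receptor (Rattus norvegicus), read by HTRF and cAMP accumulation (on this read-out higher numbers stand for larger maximal responses and lower numbers for smaller maximal responses), compound 1 reaches 81%
- compound 2, `Cc1nc(S(C)(=O)=O)ccc1Oc1ncnc(OC2CCN(C(=O)SC3(C)CC3)CC2)c1F`: in this assay compound 2 reaches 77%

Within the data shown here, compound 2 holds the lower of the two numbers, but the only step between them, a number 4 percentage points lower from compound 1 to compound 2 (within the scatter), stays within the scatter, so the two compounds cannot be told apart on maximal response. That step exchanged one group for another on the sulfur of the side chain attached to the carbonyl carbon.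

Compound 3, `Cc1nc(S(C)(=O)=O)ccc1Oc1ncnc(OC2CCN(C(=O)c3noc(C(C)(C)F)n3)CC2)c1F`, changes the same part of the molecule, but more deeply: a group of 9 heavy atoms (5 carbon, 2 nitrogen, 1 oxygen, 1 fluorine; one five-membered aromatic ring with 3 hetero atoms) in place of a group of 5 heavy atoms (4 carbon, 1 sulfur; one three-membered non-aromatic ring of carbon only), on a carbonyl carbon. The thio-ester side chain of compound 2 is wholly replaced by a fluorinated heteroaromatic ring.

Among the measured compounds shown here, only one measured step bears on this change, and it was small, within the scatter, although it altered a much smaller portion of the molecule than the present exchange. For the measured compounds named here, with no measured example of such a ring at this position, the expectation can only lean on the observation that the two measured compounds agree with each other. Compound 3 is therefore expected to give a maximal response near those of its predecessors, with a step of a number 2 percentage points lower from compound 2 to compound 3 (within the scatter), and an estimated value of 75% in a range from 55% to 95%.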

Compound 3, largest response reached (reported as efficacy), in percent of the reference or control that the assay uses: 74%
The estimate for compound 3 lay 1 percentage points above the measured number; low and high end bracket the measured number.
By their numbers in this assay, from the lowest: compounds 3, 2 and 1 (each within the scatter of the next).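

In this assay, putting the fluorinated five-membered aromatic ring on the carbonyl carbon gives a number 3 percentage points lower from compound 2 to compound 3 (within the scatter) and, measured against the isopropyl side chain, a number 7 percentage points lower from compound 1 to compound 3 (within the scatter). Among these compounds, the earlier pair showed only that one small sulfur-linked group could stand in for another, whereas these steps show that the whole sulfur-linked group can give way to a ring-bearing group of 9 heavy atoms, with 3 hydrogen-bond acceptors in place of 1, and the maximal responses still cannot be told apart. So, among these three compounds, neither the sulfur nor the three-membered carbon ring is needed for a response of this size, although no measured property here accounts for this agreement.

Going by these compounds, it remains open whether the fluorine on the new ring contributes anything, since a version with a hydrogen or a methyl group in its place would be needed to test this. Equally open, on these data alone, is whether a very different group on the same carbonyl carbon, such as an amine, a carboxylic acid or a longer alkyl chain, would also leave the maximal response unchanged.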